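The source may report more compounds than this note shows. Statements on the series, on what has been measured and on what is new or still open speak of the compounds shown alone.

Going by the values given here, compound 2 `CCC(=O)OCc1c(F)c(N)c2c(=O)cc(-c3ccc(N)c(F)c3)oc2c1F` gives 69000 nM in a functional assay on HeLa cells (Homo sapiens) for cytotoxicity, read by neutral red uptake, with a stated time of 3 days (on this read-out higher numbers stand for weaker inhibition and lower numbers for stronger inhibition), the higher of the two numbers known; compound 1 `Nc1ccc(-c2cc(=O)c3c(N)c(F)c(N)c(F)c3o2)cc1F` gives 19000 nM in this assay. Among the compounds with values here, the only measured step, a 3.6-fold higher number from compound 1 to compound 2 (0.56 log units; beyond the scatter), concerns a different exchange and does not bear directly on the change now in view. Compound 3 `CN(C)CCCOCc1c(F)c(N)c2c(=O)cc(-c3ccc(N)c(F)c3)oc2c1F` differs from compound 2 by 3-(dimethylamino)propyl in place of propanoyl on an oxygen on a saturated carbon. Within the data shown here, with no measured step touching this exchange, the step of a 1.4-fold lower number from compound 2 to compound 3 (0.14 log units; within the scatter) is expected to stay within the usual scatter. Compound 3 is therefore estimated at 50000 nM, with a range from 15000 nM to 160000 nM.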

Compound 3, half-maximal inhibitory concentration: 12000 nM
Estimate against measurement, compound 3: 4.2-fold (0.62 log units) above; measured number below the stated range.
By their numbers in this assay, from the lowest: compounds 3 and 1 (each within the scatter of the next); then compound 2.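

In this assay, going by these compounds alone, the oxygen on a saturated carbon proves sensitive to what it carries, with a step beyond the scatter (a 5.8-fold lower number from compound 2 to compound 3 (0.76 log units; beyond the scatter)), something the earlier compounds could not show. Compound 3 also stays within the scatter of compound 1 (a 1.6-fold lower number from compound 1 to compound 3 (0.20 log units; within the scatter)), so (3-(dimethylamino)propoxy)methyl and amino on that aromatic carbon cannot be told apart here, unlike (propanoyloxy)methyl and amino. No measurement shown here accounts for the change.

On these data alone, it remains open how a longer chain would read in this assay, or a morpholine or a carboxylic acid in place of the dimethylamino group.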